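This account rests on a few compounds, and the source may have more. Where it says the series, first, only, none or still open, it means among the compounds named here.

Measured compounds:
- compound 1, `CN(C)CCCNC(=O)c1cc(-c2ccc(NS(=O)(=O)c3cccc(Cl)c3Cl)cc2)nc2[nH]ncc12`: 633 nM
- compound 2, `Cc1n[nH]c2nc(-c3ccc(NS(=O)(=O)c4cc(Cl)ccc4F)cc3)nc(OCC3(CN)COC3)c12`: 1 nM
- compound 3, `Cc1n[nH]c2nc(-c3ccc(NS(=O)(=O)c4cc(Cl)ccc4F)cc3)nc(OCC(CO)CO)c12`: 2 nM

These three compounds were tested in an assay for inhibition of serine/threonine-protein kinase Sgk1 (Homo sapiens), with stated times of 30 min and 60 min, in the presence of a further agent that is not named here; a lower number here means a stronger inhibitor, a higher number a weaker inhibitor. Compound 3 holds the second highest number of the three. Its nearest neighbour is compound 2, which lies within the scatter of it, so no order between the two can be claimed; its furthest neighbour is compound 1, whose number is far higher, well beyond the scatter.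

Compound 4, `Cc1n[nH]c2nc(-c3ccc(NS(=O)(=O)c4cc(Cl)ccc4F)cc3)nc(OC3CCC(=O)CC3)c12`, has not yet been measured. Compared with compound 3 the change is 4-oxocyclohexyl in place of 3-hydroxy-2-(hydroxymethyl)propyl on an oxygen on an aromatic ring. For the measured compounds named here, only one measured step touches the same place on the shared core: a 2.0-fold higher number from compound 2 to compound 3 (0.30 log units; within the scatter), which swapped one group on that oxygen for another without moving the number beyond the scatter. That step suggests this position accepts different groups, but it involved groups that both carried hydrogen-bond donors, whereas the entering ring carries none, so it is a weaker guide.

On that basis the step is expected to be small and toward a higher number: a 2.5-fold higher number from compound 3 to compound 4 (0.40 log units; beyond the scatter). Compound 4 is therefore estimated at 5 nM, with a likely range from 1.5 nM to 20 nM.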

Compound 4, half-maximal inhibitory concentration: 18 nM
Estimate against measurement, compound 4: 3.6-fold (0.56 log units) below, within the range that was stated.
By their numbers in this assay, from the lowest: compounds 2 and 3 (each within the scatter of the next); then compound 4; then compound 1.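

In this assay the group on the oxygen on an aromatic ring clearly matters: putting 4-oxocyclohexyl in place of 3-hydroxy-2-(hydroxymethyl)propyl gives a 9.0-fold higher number from compound 3 to compound 4 (0.95 log units; beyond the scatter) and so moves beyond the scatter, whereas the earlier swap at this place, a 2.0-fold higher number from compound 2 to compound 3 (0.30 log units; within the scatter) on the same scale, stayed within it. Measured against the (3-(aminomethyl)oxetan-3-yl)methyl group, the same ketone ring gives an 18-fold higher number from compound 2 to compound 4 (1.26 log units; beyond the scatter) as a larger step, so this place does not accept every group equally, and the freedom suggested by the first pair has a limit. No measurement shown here ties these steps to any property of the groups.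

This change alters several things at once: an open chain gives way to a six-membered ring, and the hydrogen-bond donors of the chain are absent from the ketone ring, so the three compounds cannot say which of these carries the step. Still open, on these data alone, is where a 4-hydroxycyclohexyl group, with a hydroxyl on the same ring, or a 4-aminocyclohexyl group, with an amine there, would fall on this scale.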